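The source may hold more compounds than are shown below. What is called first, only, known or untested is meant among the compounds shown, and "the series" means these compounds.

Compound 1, whose structure is `O=C1/C(=C/c2cccc(Br)c2)Cc2ccccc21`, and compound 2, whose structure is `Cc1cccc(/C=C2\Cc3ccccc3C2=O)c1`, share one core, while compound 3, with the structure `O=C1CCCCC/C1=C\c1cccc(Br)c1`, and the still untested compound 4, with the structure `Cc1cccc(/C=C2\CCCCCC2=O)c1`, share another; the difference between the two cores is not broken down here.

In a functional assay on MOLT-4 cells (Homo sapiens) for inhibition (on this read-out lower numbers stand for stronger inhibition and higher numbers for weaker inhibition), compound 1 gives 173000 nM. In this assay compound 2 gives 80300 nM, and the change between them is methyl in place of bromo on an aromatic carbon, which produced a 2.2-fold lower number from compound 1 to compound 2 (0.33 log units; beyond the scatter). In this assay compound 3 gives 176000 nM, a number that sits within the usual scatter of the value of compound 1, while compound 2 stands beyond the scatter below both.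

The change leading to compound 4 is methyl in place of bromo on an aromatic carbon. Within the data shown here, it is the same kind of change as the one from compound 1 to compound 2, though the surroundings are described differently: in the first pair the methyl sits meta to a large group, in the second pair meta to a group of 9 heavy atoms. Because the same kind of change gave a 2.2-fold lower number from compound 1 to compound 2 (0.33 log units; beyond the scatter) on the other core, a step of similar size, a 2.1-fold lower number from compound 3 to compound 4 (0.32 log units; beyond the scatter), is expected here. On that basis compound 4 is estimated to give 85000 nM in this assay, with a plausible range from 45000 nM to 170000 nM, the upper end acknowledging that a single precedent on a different core is a thin footing.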

Compound 4, half-maximal inhibitory concentration: 228000 nM
Compound 4: middle estimate off by 2.7-fold (0.43 log units), on the low side; measured number above the stated range.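

Methyl in place of bromo gave a 1.3-fold higher number from compound 3 to compound 4 (0.11 log units; within the scatter) in this assay, so on the core of compound 3 this change cannot be told apart from no change at all, whereas on the core of compound 1 it moved the number beyond the scatter. This shows that, within these four compounds, the effect of the change did not carry over from one core to the other, and that a step read on one core was no safe guide to the step on the other. It does not show why the two cores differ, and with a single pair on each core it cannot say whether the gap would hold for another pair or how the change would behave on a third core, the two steps being set side by side here as they stand: the same change on two cores in this assay, a 2.2-fold lower number (0.33 log units; beyond the scatter) from compound 1 to compound 2 and a 1.3-fold higher number (0.11 log units; within the scatter) from compound 3 to compound 4, 2.8-fold (0.45 log units) apart, beyond the scatter of two such steps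

The compounds shown leave open whether chloro, methoxy or an amine in place of the bromo would also follow a different course on the two cores. They also leave open which part of the difference between the two cores goes with the gap between the steps, and whether a carboxylic acid elsewhere on either core would shift the numbers at all.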